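The compounds below may be only part of what the source reports. "The series", "measured", "known", "first", "only" and "open" are said of these compounds alone.

Measured in an ADME assay on Vero cells (Chlorocebus sabaeus) for cytotoxicity, read by resazurin assay, with a stated time of 72 h; on this read-out lower numbers stand for stronger inhibition and higher numbers for weaker inhibition:
- compound 1 `Cc1ccc(C(=O)CCN2CCN(c3ccc(C(F)(F)F)cc3)CC2)cc1`: 140000 nM
- compound 2 `COc1ccc(C(=O)CCN2CCN(c3ccc(F)cc3)CC2)cc1OC`: 175000 nM
- compound 3 `COc1ccc(C(=O)CCN2CCN(c3ccc(C(F)(F)F)cc3)CC2)cc1OC`: 243000 nM

Compound 3 has 243000 nM, which lies within the usual scatter of both other compounds. Compound 4 `O=C(CCN1CCN(c2ccc(C(F)(F)F)cc2)CC1)c1ccc(F)c(Br)c1` keeps the rest of compound 3 and changes one group: 3-bromo-4-fluorophenyl in place of 3,4-dimethoxyphenyl on a carbonyl carbon. In words, 3-bromo-4-fluorophenyl stands in place of 3,4-dimethoxyphenyl on a carbonyl carbon.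

The measured step closest to this one concerns the same place: a 1.7-fold higher number from compound 1 to compound 3 (0.24 log units; within the scatter), with 3,4-dimethoxyphenyl in place of 4-methylphenyl. The other step, a 1.4-fold higher number from compound 2 to compound 3 (0.14 log units; within the scatter), has trifluoromethyl in place of fluoro on an aromatic carbon. It concerns a different place, and compound 4 keeps the trifluoromethyl. Neither step leaves the scatter. Among the measured compounds shown here, no measured compound carries bromine, so this estimate is an extrapolation. On this evidence, the expected change in this assay is a 1.7-fold lower number from compound 3 to compound 4 (0.24 log units; within the scatter), with no step beyond the scatter anticipated. For compound 4 the estimated value is 140000 nM, with an expected range from 60000 nM to 300000 nM.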

Compound 4, half-maximal inhibitory concentration: 66800 nM
Compound 4: the middle estimate sits 2.1-fold (0.32 log units) above what was measured; the range from low to high includes it.
By their numbers in this assay, from the lowest: compound 4; then compounds 1, 2 and 3 (each within the scatter of the next).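

In this assay, the group on the carbonyl carbon can shift the number beyond the scatter: 3-bromo-4-fluorophenyl gives a 3.6-fold lower number from compound 3 to compound 4 (0.56 log units; beyond the scatter) when it replaces 3,4-dimethoxyphenyl, and a 2.1-fold lower number from compound 1 to compound 4 (0.32 log units; beyond the scatter) when it replaces 4-methylphenyl. Among the compounds shown here, the earlier exchange at this place, between 4-methylphenyl and 3,4-dimethoxyphenyl, stayed within the scatter, so this is the first sign that the place matters for the read-out, although both new steps are modest. No measurement at hand offers a reason for these steps.

As far as these compounds go, it stays open whether a 3-bromophenyl or a 4-fluorophenyl on the carbonyl carbon would give a similar step on its own. Also open, from the compounds shown here alone, is what an amine or a carboxylic acid on that aromatic ring would do to the number.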